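The source may report more compounds than this note shows. Statements on the series, on what has been measured and on what is new or still open speak of the compounds shown alone.

Going by the values given here, compound 1 `CCN1CCN(c2cc(C)c3cc(NC(=O)c4ccccc4C)ccc3n2)CC1` is one of three compounds measured in a functional assay on MCF7 cells (Homo sapiens) for antiproliferative activity, read by MTT assay, with a stated time of 72 h (a higher number here means a weaker inhibitor, a lower number a stronger inhibitor), where compound 1 gives 10900 nM. That number is the second highest of the three: compound 2 `Cc1cc(NCCN2CCN(C)CC2)nc2ccc(NC(=O)c3ccc(Cl)c(Cl)c3)cc12` gives 1700 nM in this assay, and compound 3 `Cc1cc(N(C)C)nc2ccc(NC(=O)c3ccc(Cl)c(Cl)c3)cc12` gives 33300 nM. Among the compounds with values here, the one step between measured compounds that differ in a single place runs a 20-fold higher number from compound 2 to compound 3 (1.29 log units; beyond the scatter), with dimethylamino in place of (2-(4-methylpiperazin-1-yl)ethyl)amino on an aromatic carbon.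

Compound 4 `CCN1CCN(c2cc(C)c3cc(NC(=O)c4cc(Cl)cc(Cl)c4)ccc3n2)CC1` has not yet been measured. It differs from compound 1 by 3,5-dichlorophenyl in place of 2-methylphenyl on a carbonyl carbon. Within the data shown here, no measured step bears on this change: the step from compound 2 to compound 3 concerns the amine on the core, and compounds 2 and 3 differ from compound 1 in more than one place. The amide end of the molecule is therefore untested here, so no step beyond the scatter is expected in this assay, in either direction. Compound 4 is estimated at 8000 nM in this assay, within a range of 2500 nM to 25000 nM, a step of a 1.4-fold lower number from compound 1 to compound 4 (0.13 log units; within the scatter) that is expected to stay within the scatter.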

Compound 4, half-maximal inhibitory concentration: 6090 nM
Compound 4: middle estimate off by 1.3-fold (0.12 log units), on the high side; measured number inside the range.
By their numbers in this assay, from the lowest: compound 2; then compounds 4 and 1 (each within the scatter of the next); then compound 3.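

In this assay, 3,5-dichlorophenyl in place of 2-methylphenyl on the carbonyl carbon gives a 1.8-fold lower number from compound 1 to compound 4 (0.25 log units; within the scatter), so this replacement of one aryl group by another at the amide end leaves the number within the scatter. The earlier step, a 20-fold higher number from compound 2 to compound 3 (1.29 log units; beyond the scatter), concerned only the amine on the core and said nothing about this end of the molecule. No measurement of any property bears on this result.

Going by these compounds, it remains open whether a group of another kind on the carbonyl carbon, such as a pyridine ring, a cyclohexyl ring or a longer alkyl chain, would also stay within the scatter. Also open, on these data alone, is what (2-(4-methylpiperazin-1-yl)ethyl)amino would do on the core of compound 4.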